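Hydroxymethyl in Place of Carboxy: Expecting Compound 4

The compounds below may be only part of what the source reports. "The series", "measured", "known", "first", "only" and "open" are said of these compounds alone.

Measured compounds:
compound 1 `Cc1ccc2cccc(OCc3c(C)ccc(N4CCC[C@@H]4C(=O)O)c3C)c2n1`: 1%
compound 2 `Cc1ccc2cccc(OCc3c(C)ccc(N4CCC[C@@H]4CO)c3C)c2n1`: 9%
compound 3 `Cc1ccc2cccc(OCc3c(C)ccc(N4CCC[C@H]4C(=O)O)c3C)c2n1`: 6%

In an assay on isolated protein for binding affinity to B1 bradykinin receptor (Homo sapiens), tested at 1 uM (on this read-out higher numbers stand for more inhibition at the one concentration tested (going by the name of the read-out) and lower numbers for less inhibition), compound 3 gives 6%; its number differs from those of compound 2 and compound 1 only within the scatter (a number 3 percentage points lower from compound 2 to compound 3 (within the scatter), a number 5 percentage points higher from compound 1 to compound 3 (within the scatter)). Compound 4 `Cc1ccc2cccc(OCc3c(C)ccc(N4CCC[C@H]4CO)c3C)c2n1` differs from compound 3 by hydroxymethyl in place of carboxy on a saturated ring carbon. Going by the values given here, the one measured step that bears on this change is a number 8 percentage points higher from compound 1 to compound 2 (within the scatter), the same exchange in the other configuration, and it stayed within the scatter. The step from compound 3 to compound 4 is therefore expected to be small, a number 4 percentage points higher from compound 3 to compound 4 (within the scatter), with no change beyond the scatter. Compound 4 is expected to give 10%, in a range from 0% to 22%.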

Compound 4, a percentage reported as inhibition, at one concentration (the size of the read-out at that concentration, not a potency): 1%
Beside the measured number, compound 4's estimate is 9 percentage points above it; measured number inside the range.
By their numbers in this assay, from the lowest: compounds 1, 4, 3 and 2 (each within the scatter of the next).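

In this assay, the exchange of carboxy for hydroxymethyl on this saturated ring carbon can now be read in both configurations, and the second reading, a number 5 percentage points lower from compound 3 to compound 4 (within the scatter), also stays small: the same change on two cores in this assay, a number 8 percentage points higher (within the scatter) from compound 1 to compound 2 and a number 5 percentage points lower (within the scatter) from compound 3 to compound 4, 13 percentage points apart, within the scatter of two such steps. Configuration at this carbon, so far read only with carboxy, now also makes no difference beyond the scatter with hydroxymethyl, a number 8 percentage points lower from compound 2 to compound 4 (within the scatter): the fact that compounds 2 and 4 differ only in the configuration as drawn. With both group and configuration exchanged, there is no change at the digits printed from compound 1 to compound 4 (within the scatter).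

The compounds shown leave open whether an amine or an amide on this carbon would give a step beyond the scatter.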